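Swapping a pentyl chain for a pyridinylmethyl group

The source may hold more compounds than are shown below. What is called first, only, known or untested is meant among the compounds shown, and "the series" means these compounds.

Compound 1 `COc1ccc(C(C)=O)cc1CSc1nc2cc(NC(=O)C3CC3)ccc2n1C(C)C`: in an assay on isolated protein for inhibition of Gonadotropin-releasing hormone receptor (Rattus norvegicus) (on this read-out higher numbers stand for weaker inhibition and lower numbers for stronger inhibition), compound 1 gives only an assay limit, > 10000 nM, not a number.
Compound 2 `CCCCCn1c(SCc2cc([N+](=O)[O-])ccc2OC)nc2cc(NC(=O)NC(C)(C)C)ccc21`: in this assay compound 2 gives 880 nM.

Among the compounds with values here, compound 2 therefore holds the only real number; the other value sits at the limit (the limit of > 10000 nM in this assay, at which 1 of the 2 values shown sits). Compound 3 `COc1ccc([N+](=O)[O-])cc1CSc1nc2cc(NC(=O)NC(C)(C)C)ccc2n1Cc1ccncc1` differs from compound 2 by pyridin-4-yl in place of butyl on a saturated chain carbon bound to an aromatic nitrogen. Within the data shown here, no measured pair shows this change, so its size is not known here; a shift no larger than the usual scatter, in either direction, is expected. The expected step from compound 2 to compound 3 is a 1.3-fold lower number from compound 2 to compound 3 (0.10 log units; within the scatter). Compound 3 is estimated to give 700 nM in this assay, within a range from 150 nM to 3500 nM.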

Compound 3, half-maximal inhibitory concentration: 240 nM
Estimate against measurement, compound 3: 2.9-fold (0.46 log units) above; measured number inside the range.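

Within the data shown here, this is the first step measured at this position: in this assay, replacing the pentyl chain with (pyridin-4-yl)methyl gives a 3.7-fold lower number from compound 2 to compound 3 (0.56 log units; beyond the scatter), a modest change beyond the usual scatter. On this one pair, a ring containing a nitrogen is accepted at this position, and the number falls rather than rises. Nothing measured here explains why the number falls.

One pair cannot separate the effect of the ring from that of its nitrogen. A benzyl group or a pyridin-3-ylmethyl group at this place would help to tell these apart.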